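The source may hold more compounds than are shown below. What is called first, only, known or untested is meant among the compounds shown, and "the series" means these compounds.

Compound 1 `O=c1c2cc([N+](=O)[O-])cnc2sn1-c1ccc(Br)cc1` is the strongest inhibitor among the three measured compounds: in an assay for inhibition of histone acetyltransferase KAT2B (Homo sapiens), read by fluorescence (on this read-out higher numbers stand for weaker inhibition and lower numbers for stronger inhibition), compound 1 gives 4910 nM, while compound 2 `O=c1c2cccnc2sn1Cc1ccccc1` gives 23000 nM and compound 3 `O=c1c2cccnc2sn1Cc1ccc(Cl)cc1` gives 17500 nM. Within the data shown here, the only single step among them, a 1.3-fold lower number from compound 2 to compound 3 (0.12 log units; within the scatter), concerns a chloro in place of hydrogen on the pendant ring and is too small to read. Compound 4 `O=c1c2cccnc2sn1-c1ccc(Br)cc1` differs from compound 1 by hydrogen in place of nitro on an aromatic carbon, so the nitro leaves the shared core. Among the measured compounds shown here, no measured step touches this position, and compounds 2 and 3, which also lack the nitro but carry a benzyl rather than the bromophenyl of compound 1, weigh in only loosely. A loss of potency is therefore expected for compound 4, with a step of a 3.1-fold higher number from compound 1 to compound 4 (0.49 log units; beyond the scatter), giving an estimated value of 15000 nM in this assay, within a range from 5000 nM to 45000 nM.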

Compound 4, half-maximal inhibitory concentration: 4430 nM
The estimate for compound 4 lay 3.4-fold (0.53 log units) above the measured number; measured number outside the range, below it.
By their numbers in this assay, from the lowest: compounds 4 and 1 (each within the scatter of the next); then compounds 3 and 2 (each within the scatter of the next).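

Hydrogen in place of nitro on this aromatic carbon, two atoms from the ring nitrogen, gives a 1.1-fold lower number from compound 1 to compound 4 (0.04 log units; within the scatter) in this assay and so no readable change. With the bromophenyl in place, the nitro is therefore not needed for the inhibition seen with compound 1. Nothing available here offers a reason for this result. As far as these compounds go, whether another group at this position, such as an amine or a carboxylic acid, would shift the number stays open. So does whether nitro would matter on a benzyl compound such as compound 2.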